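The source may report more compounds than this note shows. Statements on the series, on what has been measured and on what is new or still open speak of the compounds shown alone.

In a functional assay on 4T1 cells (Mus musculus) for cytotoxicity, read by MTT assay, with a stated time of 24 h (a lower number here means a stronger inhibitor, a higher number a weaker inhibitor), compound 1, with structure `COc1ccc(/C=C2\CN(Cc3cn(Cc4cccc(Cl)c4)nn3)C/C(=C\c3ccc(OC)cc3)C2=O)cc1`, gives 56600 nM. This is the highest number among the three compounds measured, meaning the weakest inhibition. Compound 2 `Cc1ccc(/C=C2\CN(Cc3cn(Cc4ccccc4F)nn3)C/C(=C\c3ccc(C)cc3)C2=O)cc1` gives 18000 nM in this assay, and compound 3 `O=C1/C(=C/c2ccccc2F)CN(Cc2cn(Cc3ccccc3F)nn2)C/C1=C\c1ccccc1F` gives 6500 nM; both numbers lie well below that of compound 1, beyond the usual scatter, but neither compound differs from compound 1 in only one place, so no single change can be tied to these gaps.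

Compound 4 `COc1ccc(/C=C2\CN(Cc3cn(Cc4ccccc4Cl)nn3)C/C(=C\c3ccc(OC)cc3)C2=O)cc1` differs from compound 1 in one way only: 2-chlorophenyl in place of 3-chlorophenyl on a saturated chain carbon bound to an aromatic nitrogen. Nothing measured here isolates this kind of change. The expected step from compound 1 to compound 4 is therefore a 1.3-fold lower number from compound 1 to compound 4 (0.10 log units; within the scatter), a small shift that may not exceed the scatter. For compound 4 in this assay the estimate is 45000 nM, with a range from 15000 nM to 130000 nM.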

Compound 4, half-maximal inhibitory concentration: 11400 nM
The estimate for compound 4 lay 3.9-fold (0.60 log units) above the measured number; the measured number lies below the stated range.
By their numbers in this assay, from the lowest: compounds 3, 4 and 2 (each within the scatter of the next, the first and the last beyond it); then compound 1.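

In this assay, 2-chlorobenzyl in place of 3-chlorobenzyl gives a 5.0-fold lower number from compound 1 to compound 4 (0.70 log units; beyond the scatter). Among these compounds, this is the first single-place comparison, and it shows that with the same atoms joined differently, the number at this place, on a saturated chain carbon bound to an aromatic nitrogen, shifts beyond the scatter. Nothing measured here explains the step.

The compounds shown leave open whether this exchange gives a similar step on the cores of compound 2 and compound 3. They also leave open how 4-chlorobenzyl or a benzyl group carrying a carboxylic acid would compare at this place.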